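The source may hold more compounds than are shown below. What is called first, only, known or untested is meant among the compounds shown, and "the series" means these compounds.

Measured in a functional assay on K562 cells (Homo sapiens) for cytotoxicity, read by MTT assay, with a stated time of 48 h; a lower number here means a stronger inhibitor, a higher number a weaker inhibitor:
- compound 1 `Cc1ccccc1CN1CCN(C(=O)CN[C@H]2CCN(S(=O)(=O)Cc3ccccc3)C2)CC1`: 10200 nM
- compound 2 `O=C(CN[C@H]1CCN(S(=O)(=O)Cc2ccccc2)C1)N1CCN(Cc2ccccc2Cl)CC1`: 9000 nM
- compound 3 `O=C(CN[C@H]1CCN(S(=O)(=O)Cc2ccccc2)C1)N1CCN(Cc2cccc(C(F)(F)F)c2)CC1`: 3600 nM

Compound 3 has the lowest number of the three, and its steps to the other two lie beyond the scatter. The move to compound 4 `Cc1cc(C)c(CN2CCN(C(=O)CN[C@H]3CCN(S(=O)(=O)Cc4ccccc4)C3)CC2)c(C)c1` is 2,4,6-trimethylphenyl in place of 3-(trifluoromethyl)phenyl on a saturated chain carbon bound to an amine nitrogen in a ring. The closest evidence is the arrival of 3-(trifluoromethyl)phenyl itself, a 2.8-fold lower number from compound 1 to compound 3 (0.45 log units; beyond the scatter), and likewise a 2.5-fold lower number from compound 2 to compound 3 (0.40 log units; beyond the scatter). Chloro in place of methyl gave a 1.1-fold lower number from compound 1 to compound 2 (0.05 log units; within the scatter). Among the measured compounds shown here, both modest steps lead down to compound 3, so a modest step back up is expected, although no measured compound carries 2,4,6-trimethylphenyl. The expected change is a 1.8-fold higher number from compound 3 to compound 4 (0.26 log units; within the scatter). For compound 4 the estimate is 6500 nM, with an expected range of 2800 nM to 13000 nM.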

Compound 4, half-maximal inhibitory concentration: 3300 nM
For compound 4 the middle estimate is 2.0-fold (0.29 log units) above the measured one, within the range that was stated.
By their numbers in this assay, from the lowest: compounds 4 and 3 (each within the scatter of the next); then compounds 2 and 1 (each within the scatter of the next).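

In this assay, 2,4,6-trimethylphenyl on a saturated chain carbon bound to an amine nitrogen in a ring cannot be told apart from 3-(trifluoromethyl)phenyl, with a 1.1-fold lower number from compound 3 to compound 4 (0.04 log units; within the scatter) and no separation between them. The gain over the other two groups therefore does not depend on trifluoromethyl, since there is a 2.7-fold lower number from compound 2 to compound 4 (0.44 log units; beyond the scatter) and also a 3.1-fold lower number from compound 1 to compound 4 (0.49 log units; beyond the scatter) with a group of carbon only. Nothing shown here explains why these two different groups give such similar numbers.

On these data alone, whether an amine or a carboxylic acid on this benzyl ring would keep the number this low remains open. So does the effect of a longer chain in place of the benzyl carbon.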